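The source may report more compounds than this note shows. Statements on the series, on what has been measured and on what is new or still open speak of the compounds shown alone.

Measured compounds:
Compound 1, `CCN(c1ccc(C#N)c(Cl)c1)c1cc(-c2cccs2)ccc1C`: in a functional assay on VCaP cells (Homo sapiens) for antiproliferative activity, read by CCK-8 assay, with a stated time of 6 days (a higher number here means a weaker inhibitor, a lower number a stronger inhibitor), compound 1 gives "not determined" (no result reported).
Compound 2, `CCN(c1ccc(C#N)c(Cl)c1)c1cc(-c2cnc3ccccc3c2)ccc1C`: in this assay compound 2 gives 25300 nM.

Compound 1 stands without a number, so its place cannot be fixed. Compound 3, `CCN(c1ccc(C#N)c(Cl)c1)c1cc(-c2c[nH]nc2C)ccc1C`, differs from compound 1 by 3-methyl-1H-pyrazol-4-yl in place of thiophen-2-yl on an aromatic carbon. Among the compounds with values here, no step between measured compounds exists, so the data give no measured size or direction for this change; the only anchor is compound 2, whose result in this assay shows weak inhibition. The step from compound 1 to compound 3 in this assay is expected to be small, in either direction, probably not beyond the scatter. Compound 3 is estimated at 9000 nM, with a range from 1500 nM to 40000 nM.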

Compound 3, half-maximal inhibitory concentration: 3190 nM
Compound 3: middle estimate off by 2.8-fold (0.45 log units), on the high side; measured number inside the range.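

Within the data shown here, compound 1 has no number to set against compound 3, so no step between them can be read. On these data alone, whether 3-methyl-1H-pyrazol-4-yl in place of thiophen-2-yl strengthens or weakens inhibition stays open. No evidence on a cause is available.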